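Compound 1 to compound 4: bromo in place of chloro

The source may hold more compounds than are shown below. What is called first, only, known or untested is meant among the compounds shown, and "the series" means these compounds.

- Compound 1 `COC(=O)c1c[nH]c2cc(OCCOc3ccccc3)c(Cl)cc2c1=O`: > 20000 nM (a limit)
- Compound 2 `COC(=O)c1c[nH]c2ccccc2c1=O`: > 20000 nM (a limit)
- Compound 3 `COC(=O)c1c[nH]c2cc(OCCCc3ccccc3)ccc2c1=O`: 1480 nM (a number)

These values come from an ADME assay on J774 cells (Mus musculus) for cytotoxicity (a lower number here means that less compound is needed, a higher number that more compound is needed for the effect), and most of them are not numbers. Compound 1 stands at the limit of > 20000 nM in this assay, at which 2 of the 3 values shown sit, and so has no exact value. For the measured compounds named here, compound 3 is the only measured compound with a number, and it carries neither chloro nor bromo.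

Compound 4 `COC(=O)c1c[nH]c2cc(OCCOc3ccccc3)c(Br)cc2c1=O` keeps the core of compound 1. The single difference bromo in place of chloro on an aromatic carbon is bromo in place of chloro on an aromatic carbon, ortho to a large group. Going by the values given here, no measured pair shows this exchange, so its size can only be judged from the structural change and from where compound 1 stands.

The expectation is no step beyond the scatter in this assay and a result that again reaches the limit. Any number that does appear is expected on the lower side of that limit. The expected step is a number no higher from compound 1 to compound 4 (the limit leaves the size open) and it rests on compound 1 at > 20000 nM (itself a limit).

For compound 4 the estimate is 20000 nM with an expected range from 7000 nM to 40000 nM in this read-out.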

Compound 4, half-maximal effective concentration: > 20000 nM
Compound 4: only a limit was reported; the forecaster's own chance of this, stated with the estimate: 70%; the middle value sits exactly at the limit.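

In this assay compound 4 gives > 20000 nM, a limit and not a number. Compound 1 gives > 20000 nM, also a limit, so no step can be read for bromo in place of chloro between compound 1 and compound 4. The compounds shown leave open whether bromo and chloro differ at all in this assay, with neither compound carrying an exact value: the limit of > 20000 nM in this assay, at which 3 of the 4 values shown sit.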